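A few compounds are considered here, and "the series" means these few. Any claim that something is new, unique, unknown or untested is made for them only; others in the source may bear on it.

Measured compounds: compound 1 `O=C1C=CCC(/C=C/c2ccccc2)N1` with 798 uM, and compound 2 `COc1ccc(/C=C/C2CC=CC(=O)N2)cc1` with 981 uM.

Both were measured in a functional assay on U-251 cells (Homo sapiens) for inhibition, read by sulforhodamine B assay, with a stated time of 48 h; on this read-out lower numbers stand for stronger inhibition of growth and higher numbers for weaker inhibition of growth. Compound 2 gives the highest number of the two, yet the step of a 1.2-fold higher number from compound 1 to compound 2 (0.09 log units; within the scatter) lies within the scatter, so the two compounds cannot be told apart on these numbers.

Compound 3 `COc1ccc(/C=C/C2CC=CC(=O)N2)cc1OC` has not been measured. It differs from compound 2 by methoxy in place of hydrogen on an aromatic carbon. Within the data shown here, the only step that bears on this change is the one from compound 1 to compound 2, where the same kind of substitution gave a 1.2-fold higher number from compound 1 to compound 2 (0.09 log units; within the scatter), a change within the scatter. With a single relevant step of that size, the account expects no step beyond the scatter in this assay for compound 3 either.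

Compound 3 is therefore estimated at 1000 uM, with a range from 500 uM to 2000 uM, an expected step of a 1.0-fold higher number from compound 2 to compound 3 (0.01 log units; within the scatter).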

Compound 3, concentration for growth inhibition (reported as GI): > 964 uM
Compound 3: only a limit was reported; the forecaster's own chance of this, stated with the estimate: 25%; the middle value is on the limit's open side.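

In this assay, among these compounds, compound 3 gave only a limit, > 964 uM, so no step from compound 2 to compound 3 can be read. The compounds shown leave open whether the added methoxy of compound 3 changes growth inhibition at all, and by how much.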